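The source may hold more compounds than are shown below. What is called first, only, known or untested is meant among the compounds shown, and "the series" means these compounds.

Compound 1 `COc1ccc(C2N=C(SCc3ccc(Cl)cc3)NC(C)=C2C(=O)Nc2ccc(F)cc2)cc1OC` gives 24.1%.
Compound 2 `COc1ccc(C2N=C(SCc3cccc(Cl)c3)NC(C)=C2C(=O)Nc2ccc(Br)cc2)cc1` gives 33.8%.
Compound 3 `CC1=C(C(=O)Nc2ccc([N+](=O)[O-])cc2)C(c2ccc(Br)cc2)N=C(SCc2ccccc2)N1` gives 27.7%.

These three numbers come from a functional assay on the whole organism (artery, strain albino) with Rattus norvegicus as the target, with a stated time of 240 min, at a dose of 10 mg/kg by the oral route; on this read-out higher numbers stand for more inhibition at the one dose given (going by the name of the read-out) and lower numbers for less inhibition. Compound 3 holds the second highest of the three values, yet its gap to compound 1, the nearest, and its gap to compound 2, the furthest, both lie within the usual scatter of this kind of measurement, so the three compounds cannot truly be told apart on these numbers.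

Compound 4 `CC1=C(C(=O)Nc2ccc([N+](=O)[O-])cc2)C(c2ccc(Br)cc2)N=C(SCc2cccc(Cl)c2)N1` has not yet been measured. It differs from compound 3 in one place: chloro in place of hydrogen on an aromatic carbon. Among the compounds with values here, compound 2 also carries a 3-chlorobenzyl group on its sulfur, but it differs from compound 3 in other places as well, so no clean step for this single change exists among the measured compounds. All three measured values sit close together, so the step in this assay from compound 3 to compound 4 is expected to stay within the scatter, with no clear direction. On that basis compound 4 is expected to give about 30%, within a range from 15% to 45%, which means an expected step of a number 2.3 percentage points higher from compound 3 to compound 4 (within the scatter).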

Compound 4, a percentage reported as inhibition, in the whole organism at one dose (the size of the read-out at that dose, not a potency): 11.8%
Beside the measured number, compound 4's estimate is 18.2 percentage points above it; measured number below the stated range.
By their numbers in this assay, from the lowest: compound 4; then compounds 1, 3 and 2 (each within the scatter of the next).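

In this assay, within the data shown here, swapping hydrogen for chloro, which turns benzyl into 3-chlorobenzyl, gives a number 15.9 percentage points lower from compound 3 to compound 4 (beyond the scatter) and is the only clean single-place change available here. Among these compounds, it shows that this aromatic carbon is not a neutral spot: one added heavy atom, with the rest of the molecule unchanged, is enough to lower the inhibition seen at the one oral dose, something the earlier compounds, which differ in several places at once, could not reveal. Nothing available explains why the number falls.

On these data alone, whether this drop belongs to chloro itself or would follow any group on this carbon remains open, and a methyl or a methoxy in the same place would help separate the two. A single step also leaves open whether the same change would lower the number on a different amide.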